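Benzyloxy in Place of 3-Methoxyphenyl on the Shared Core

This account rests on a few compounds, and the source may have more. Where it says the series, first, only, none or still open, it means among the compounds named here.

Measured compounds:
compound 1 `COc1cccc(-c2ccc([C@H]3S[C@@H](C)C(=O)Nc4c3c(C)nn4-c3ccccc3C)cc2)c1` gives 1800 nM in an assay on isolated protein for agonist activity at Bile acid receptor (Homo sapiens), read by AlphaScreen, with a stated time of 30 min; on this read-out lower numbers stand for an effect already at smaller amounts and higher numbers for an effect only at larger amounts of compound
compound 2 `COc1cc([C@H]2S[C@@H](C)C(=O)Nc3c2c(C)nn3-c2ccccc2C)ccc1Oc1ccccc1` gives 1900 nM in this assay

Of the compounds shown here, two sharing one core have been measured in this assay. Compound 1 has the lowest of the two numbers, but compound 2 sits so close to it that the two values lie within the scatter of repeated measurements, so no order between them can be read from these data.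

Compound 3 `Cc1ccccc1-n1nc(C)c2c1NC(=O)[C@H](C)S[C@@H]2c1ccc(OCc2ccccc2)cc1` has not yet been measured in this assay. It differs from compound 1 in one place: benzyloxy in place of 3-methoxyphenyl on an aromatic carbon. Within the data shown here, no pair of measured compounds differing in one place is available, so the size of this step cannot be read from a comparison; the only guide is that compound 1 and compound 2, which differ in their outer group, give almost the same number.

On that basis compound 3 is expected to stay near compound 1, with at most a small step toward a higher number, a 1.4-fold higher number from compound 1 to compound 3 (0.14 log units; within the scatter). The estimated value for compound 3 in this assay is 2500 nM, expected to fall between 700 nM and 9000 nM.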

Compound 3, half-maximal effective concentration: "not active" (no number reported)
Compound 3: no number reported; there is nothing to compare the estimate with.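

In this assay, among these compounds, compound 3 is reported as not active, without a number, so no step from compound 1 can be read. Nothing shown here offers an explanation for this result. The compounds shown leave open how benzyloxy in place of 3-methoxyphenyl on the shared core relates to this outcome.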